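Amine nitrogen substituent variation on the shared core

The source may report more compounds than this note shows. Statements on the series, on what has been measured and on what is new or still open speak of the compounds shown alone.

Measured so far in a functional assay (strain AB) with Danio rerio as the target, read by microscopy, with a stated time of 1 h; a lower number here means that less compound is needed, a higher number that more compound is needed for the effect:
compound 1 `CC(C)CN1CCc2c(sc(NC(=O)Nc3ccc(Cl)cc3)c2C(N)=O)C1`: 4510 nM
compound 2 `CC(C)(C)OC(=O)CN1CCc2c(sc(NC(=O)Nc3ccc(Cl)cc3)c2C(N)=O)C1`: > 25000 nM (a limit of the assay)
compound 3 `COCCCN1CCc2c(sc(NC(=O)Nc3ccc(Cl)cc3)c2C(N)=O)C1`: 2400 nM

Compound 3 holds the lowest of the two numbers in this assay; the nearest is compound 1, and the step of a 1.9-fold lower number from compound 1 to compound 3 (0.27 log units; within the scatter) stays within the scatter, so no order between them is claimed. For compound 2 only a limit is reported (the limit of > 25000 nM in this assay, at which 1 of the 3 values shown sits), and the step of an at least 10-fold lower number from compound 2 to compound 3 (1.01 log units; beyond the scatter) is large.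

Compound 4 `CC(C)N1CCc2c(sc(NC(=O)Nc3ccc(Cl)cc3)c2C(N)=O)C1` differs from compound 3 in one place: isopropyl in place of 3-methoxypropyl on an amine nitrogen in a ring. The step that bears on this is a 1.9-fold lower number from compound 1 to compound 3 (0.27 log units; within the scatter), where a related branched alkyl stood on the same nitrogen and the number hardly moved. The tert-butoxycarbonyl case, an at least 5.5-fold higher number from compound 1 to compound 2 (0.74 log units; beyond the scatter), shows that a bulkier substituent here can push the number up, but isopropyl is the smaller group of the pair. A step within the scatter is therefore expected, if anything toward the number of compound 1. Compound 4 is expected to give about 3500 nM, between 1500 nM and 9000 nM. The expected step of a 1.5-fold higher number from compound 3 to compound 4 (0.16 log units; within the scatter) is estimated to stay within the scatter.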

Compound 4, half-maximal effective concentration: 1490 nM
Compound 4: the middle estimate sits 2.3-fold (0.37 log units) above what was measured; the whole stated range lies above it.
By their numbers in this assay, from the lowest: compounds 4, 3 and 1 (each within the scatter of the next, the first and the last beyond it). At a limit, above all of these: compound 2.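

In this assay, for the compounds shown here, the step of a 3.0-fold lower number from compound 1 to compound 4 (0.48 log units; beyond the scatter) is the only one among compound 1, compound 3 and compound 4 to lie beyond the scatter, and it separates isopropyl from isobutyl on the amine nitrogen in a ring. The step of a 1.6-fold lower number from compound 3 to compound 4 (0.21 log units; within the scatter) stays within the scatter, so in this pair the hydrogen-bond acceptor of 3-methoxypropyl is not required for a number in this range. The step of an at least 16-fold lower number from compound 2 to compound 4 (1.22 log units; beyond the scatter) sets compound 2 well apart from the alkyl groups, and compound 2 is reported only as a limit: the limit of > 25000 nM in this assay, at which 1 of the 4 values shown sits.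

Open, from the compounds shown here alone, is how far the number moves with a smaller group on this nitrogen, such as methyl or ethyl, or with the hydrogen of the free ring amine. Also open, going by these compounds, is how a chain carrying a carboxylic acid or a primary amine would read here.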